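Cytotoxicity series: removing the aromatic methyl from compound 3

The compounds below may be only part of what the source reports. "The series", "measured", "known", "first", "only" and "open" are said of these compounds alone.

Measured compounds:
Compound 1, `CCC(=O)c1ccc2c(c1O)[C@@H]1c3c(ccc4c(=O)c(C)c(C)oc34)OC[C@@H]1C(C)(C)O2`, in a functional assay on A549 cells (Homo sapiens) for cytotoxicity, read by MTT assay (a lower number here means a stronger inhibitor, a higher number a weaker inhibitor), gives > 100000 nM, a limit of the assay.
Compound 2, `CC(=O)c1ccc2c(c1O)[C@@H]1c3c(ccc4c(=O)c(C)c(C)oc34)OC[C@@H]1C(C)(C)O2`, in this assay gives > 100000 nM, also a limit.
Compound 3, `Cc1oc2c3c(ccc2c(=O)c1C)OC[C@H]1[C@@H]3c2c(ccc(C(=O)c3ccccc3)c2O)OC1(C)C`, in this assay gives > 100000 nM, likewise a limit.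

Compound 3 therefore stands at the limit and nowhere else; no number for it is known, and the same holds for the other two, since all three values sit at the limit of > 100000 nM in this assay, at which 3 of the 3 values shown sit. The measured steps are accordingly unreadable: a step that the two limits leave unreadable from compound 1 to compound 2, a step that the two limits leave unreadable from compound 1 to compound 3 and a step that the two limits leave unreadable from compound 2 to compound 3 give no size and no direction.

Compound 4, `Cc1coc2c3c(ccc2c1=O)OC[C@H]1[C@@H]3c2c(ccc(C(=O)c3ccccc3)c2O)OC1(C)C`, differs from compound 3 by hydrogen in place of methyl on an aromatic carbon. Among the measured compounds shown here, none of the measured steps touches this position, and none is readable in any case, so nothing points to a change beyond the scatter. Compound 4 is expected to remain at the limit, estimated at 100000 nM with a range from 30000 nM to 300000 nM. The expected step of a number no higher from compound 3 to compound 4 (the limit leaves the size open) is thus none beyond the scatter.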

Compound 4, half-maximal inhibitory concentration: 17000 nM
The estimate for compound 4 lay 5.9-fold (0.77 log units) above the measured number; measured number outside the range, below it.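

In this assay, hydrogen in place of methyl on the aromatic carbon next to the ring oxygen gives an at least 5.8-fold lower number from compound 3 to compound 4 (0.76 log units; beyond the scatter), so this position, unlike the changes on the carbonyl carbon, can move the read-out off the limit. The size is only a lower bound, and the steps among compound 1, compound 2 and compound 3 cannot be read. Compound 4 is the only compound shown with a number rather than a limit: the limit of > 100000 nM in this assay, at which 3 of the 4 values shown sit.

Going by these compounds, whether ethyl, a methoxy group or a chlorine atom at this position would also give a readable number remains open. Also open, on these data alone, is whether the same removal of methyl would give a readable number with ethyl or methyl on the carbonyl carbon, as in compound 1 and compound 2, rather than phenyl.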